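Dichlorophenyl Variation on a Cytotoxic Sulfonamide Series

This account rests on a few compounds, and the source may have more. Where it says the series, first, only, none or still open, it means among the compounds named here.

In a functional assay on C8166 cells (Homo sapiens) for cytotoxicity, read by MTT assay (a lower number here means that less compound is tolerated, a higher number that more compound is tolerated), compound 1 `Cc1cccc(C(=O)Nc2cc(Cl)ccc2OCC(=O)Nc2ccc(S(N)(=O)=O)cc2C)c1` gives 52900 nM. Compound 2 `Cc1ccc(C(=O)Nc2cc(Cl)ccc2OCC(=O)Nc2ccc(S(N)(=O)=O)cc2C)c(C)c1` gives 47600 nM and compound 3 `Cc1cc(S(N)(=O)=O)ccc1NC(=O)COc1ccc(Cl)cc1NC(=O)c1cc(Cl)ccc1Cl` gives 42100 nM; the step of a 1.1-fold lower number from compound 1 to compound 2 (0.05 log units; within the scatter) and the step of a 1.3-fold lower number from compound 1 to compound 3 (0.10 log units; within the scatter) both lie within the scatter, so compound 1 is not separated from either. Compound 4 `Cc1cc(S(N)(=O)=O)ccc1NC(=O)COc1ccc(Cl)cc1NC(=O)c1ccc(Cl)c(Cl)c1` carries 3,4-dichlorophenyl in place of 3-methylphenyl on a carbonyl carbon. Among the compounds with values here, the steps that bear on it are the two changes at the same carbonyl carbon, a 1.1-fold lower number from compound 1 to compound 2 (0.05 log units; within the scatter) and a 1.3-fold lower number from compound 1 to compound 3 (0.10 log units; within the scatter), neither of which moved the number beyond the scatter, and the move from compound 2 to compound 3, a 1.1-fold lower number from compound 2 to compound 3 (0.05 log units; within the scatter), did not either. No step beyond the scatter is therefore expected in this assay. Compound 4 is estimated at 45000 nM, between 25000 nM and 80000 nM, an expected step of a 1.2-fold lower number from compound 1 to compound 4 (0.07 log units; within the scatter).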

Compound 4, half-maximal cytotoxic concentration: 158000 nM
Beside the measured number, compound 4's estimate is 3.5-fold (0.55 log units) below it, and the stated range ends below it.
By their numbers in this assay, from the lowest: compounds 3, 2 and 1 (each within the scatter of the next); then compound 4.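

Moving to 3,4-dichlorophenyl on this carbonyl carbon gives a 3.0-fold higher number from compound 1 to compound 4 (0.48 log units; beyond the scatter) and a 3.3-fold higher number from compound 2 to compound 4 (0.52 log units; beyond the scatter) in this assay and these are the first steps at this position beyond the scatter. Since a 3.8-fold higher number from compound 3 to compound 4 (0.57 log units; beyond the scatter) links two dichlorophenyl groups, having two chlorines on the ring does not by itself set the number; their placement does. Nothing available explains this difference.

The compounds shown leave open whether one chlorine alone, as in 3-chlorophenyl or 4-chlorophenyl, would give the same change. They also leave open how a 3,4-dimethylphenyl group would compare.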